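The source may hold more compounds than are shown below. What is called first, only, known or untested is meant among the compounds shown, and "the series" means these compounds.

Measured so far:
- Compound 1, `Cn1c(=O)c(=O)n(C2CCCC2)c2nc(N/N=C/c3ccccc3)ncc21`: in a functional assay on HCT-116 cells (Homo sapiens) for antiproliferative activity, read by MTT assay (on this read-out lower numbers stand for stronger inhibition and higher numbers for weaker inhibition), compound 1 gives > 100000 nM, which is a limit of the assay and not a number.
- Compound 2, `Cn1c(=O)c(=O)n(C2CCCC2)c2nc(N/N=C/c3ccc(O)c(F)c3)ncc21`: in this assay compound 2 gives 59300 nM.

Among the compounds with values here, compound 2 thus stands as the only compound with a numerical result in this assay; the other value shown is a limit, as noted in the limit of > 100000 nM in this assay, at which 1 of the 2 values shown sits. Within the data shown here, the one measured step runs an at least 1.6-fold lower number from compound 1 to compound 2 (0.22 log units; that floor lies within the scatter), and its floor lies within the scatter, so it says little about how large an effect a change on this ring can have.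

Compound 3, `Cn1c(=O)c(=O)n(C2CCCC2)c2nc(N/N=C/c3ccc(O)c(Br)c3)ncc21`, differs from compound 2 by bromo in place of fluoro on an aromatic carbon. Among the measured compounds shown here, no measured step exchanges one halogen for another at this place, so the expectation rests on the near absence of movement in the single step available. Compound 3 is therefore expected to sit close to compound 2, with an estimated step of a 1.3-fold lower number from compound 2 to compound 3 (0.12 log units; within the scatter) in this assay, no larger than the scatter. The estimate for compound 3 is 45000 nM, ranging from 15000 nM to 130000 nM.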

Compound 3, half-maximal inhibitory concentration: 17700 nM
For compound 3 the middle estimate is 2.5-fold (0.41 log units) above the measured one; the range from low to high includes it.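

In this assay, the exchange of fluoro for bromo on the aromatic carbon ortho to the hydroxy group gives a 3.4-fold lower number from compound 2 to compound 3 (0.53 log units; beyond the scatter). Within the data shown here, this is the first step between two numerical values, and it shows that the identity of the halogen at this place changes the result beyond the scatter, which the single earlier step could not show. Going from the unsubstituted phenyl, 3-bromo-4-hydroxyphenyl gives an at least 5.6-fold lower number from compound 1 to compound 3 (0.75 log units; beyond the scatter), now also beyond the scatter, though compound 1 stands at a limit of the assay and not at a number, so this step is only a floor: the limit of > 100000 nM in this assay, at which 1 of the 3 values shown sits.

The compounds shown do not separate the share of the hydroxy group from that of the halogen, since both always enter the phenyl ring together. From the compounds shown here alone, it also remains open whether chloro or iodo at this place would follow the change from fluoro to bromo, and whether a methoxy group or an amine in place of the hydroxy group would keep the result of compound 3.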